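Methyl for Isopropyl on a Ring Nitrogen

A few compounds are considered here, and "the series" means these few. Any claim that something is new, unique, unknown or untested is made for them only; others in the source may bear on it.

Among the measured compounds shown here, compound 1 `CC(C)n1ncnc1-c1ccccc1NCC1=NCCN1` is one of three compounds tested so far in a functional assay with Alpha-1B adrenergic receptor (Homo sapiens) as the target, read by calcium flux; on this read-out higher numbers stand for larger maximal responses and lower numbers for smaller maximal responses. In this assay compound 1 reaches 0%. Compound 2 `CCn1ccc(-c2ccccc2NCC2=NCCN2)n1` gives 0% in this assay, and compound 3 `CCCn1nccc1-c1ccccc1NCC1=NCCN1` gives 0%. Compound 1 thus stands level with compounds 2 and 3, with no difference beyond the scatter in either direction: none of the three produces a measurable response.

Compound 4 `Cn1ncnc1-c1ccccc1NCC1=NCCN1` has not been measured yet. It differs from compound 1 at a single place: methyl in place of isopropyl on an aromatic nitrogen. Isopropyl gives way to methyl on the aromatic nitrogen, and nothing else in the molecule changes.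

For the measured compounds named here, no pair of measured compounds differing in one place is available, so no step size can be read off. Since compound 1 shows 0% and its companions, which differ more widely from it, show the same absence of response, a step of about a number 2 percentage points higher from compound 1 to compound 4 (within the scatter) is expected, that is, none beyond the scatter. Compound 4 is therefore expected to give 2% in this assay, within 0% to 12%.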

Compound 4, largest response reached (reported as maximal response), in percent of the reference or control that the assay uses: 93%
Beside the measured number, compound 4's estimate is 91 percentage points below it; measured number above the stated range.
By their numbers in this assay, from the lowest: compounds 1, 2 and 3 (each within the scatter of the next); then compound 4.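

Putting methyl in place of isopropyl on the aromatic nitrogen gives a number 93 percentage points higher from compound 1 to compound 4 (beyond the scatter) in this assay, so this single position can decide between no measurable response and a large one. The zero of compound 1 therefore does not rule out its core as a whole, since the same core with methyl on this nitrogen does respond, and the difference lies in a swap from a group of 3 heavy atoms to one of 1. Nothing at hand explains why this exchange has so large an effect.

From the compounds shown here alone, what remains open is how much room this nitrogen allows between methyl and isopropyl, a question that a cyclopropyl group there could help to answer. Equally open, going by these compounds, is whether any carbon group is needed at all, which a plain hydrogen on this nitrogen would address.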